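Replacing Ethylsulfanyl with 3-Chlorophenoxy in a Sodium/Hydrogen Exchanger Series

The compounds below may be only part of what the source reports. "The series", "measured", "known", "first", "only" and "open" are said of these compounds alone.

Compound 1, `CS(=O)(=O)c1cc(C(=O)N=C(N)N)c(Cl)cc1Cl`: 140 nM
Compound 2, `Cc1c(C(=O)N=C(N)N)ccc(Cl)c1S(C)(=O)=O`: 1300 nM
Compound 3, `CCSc1cc(C)c(C(=O)N=C(N)N)cc1S(C)(=O)=O`: 5.9 nM

Of the compounds shown here, three of the shared acylguanidine core have been measured in a functional assay for inhibition of sodium/hydrogen exchanger (Oryctolagus cuniculus); a higher number here means a weaker inhibitor, a lower number a stronger inhibitor. Compound 3 gives the lowest number of the three, with 5.9 nM. Compound 1 is the nearest to it and gives 140 nM, a gap well beyond the scatter. Compound 2 stands furthest away with 1300 nM. None of these three pairs differs in only one place, so no single step can be read from the measured set.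

The next compound, compound 4, `Cc1cc(Oc2cccc(Cl)c2)c(S(C)(=O)=O)cc1C(=O)N=C(N)N`, has not yet been measured. It derives from compound 3 by one change: 3-chlorophenoxy in place of ethylsulfanyl on an aromatic carbon.

Going by the values given here, no measured pair shows what an exchange of this kind does here, so the direction of the step rests on the numbers alone. Since compound 3 already holds the lowest value, and the entering group is far larger than the group it replaces, a move toward a higher number is expected, of moderate size. The step from compound 3 to compound 4 is expected to be a 2.5-fold higher number from compound 3 to compound 4 (0.41 log units; beyond the scatter). For compound 4 the estimate is 15 nM, with a range from 3 nM to 80 nM.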

Compound 4, half-maximal inhibitory concentration: 21 nM
The estimate for compound 4 lay 1.4-fold (0.15 log units) below the measured number; measured number inside the range.
By their numbers in this assay, from the lowest: compound 3; then compound 4; then compound 1; then compound 2.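

In this assay, going by these compounds alone, the exchange of ethylsulfanyl for 3-chlorophenoxy provides the first step in this set that can be read at a single place: a 3.6-fold higher number from compound 3 to compound 4 (0.55 log units; beyond the scatter), a modest move that lies beyond the scatter. The position, an aromatic carbon ortho to the methylsulfonyl group and meta to the methyl group, therefore takes a group of 8 heavy atoms with a six-membered aromatic ring in place of a group of 3 heavy atoms with no ring, and the number rises only modestly. No measurement shown here bears on why the step has this direction or size.

Open, on these data alone, is how a plain phenoxy group or a 4-chlorophenoxy group would compare at this carbon, and so whether the chlorine or its placement on the entering ring has any part in the step. Equally open, as far as these compounds go, is what a methoxy group, with its oxygen link but no ring, or a piperidine ring, linked through nitrogen, would give in this position on the shared core.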